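The source may report more compounds than this note shows. Statements on the series, on what has been measured and on what is new or still open speak of the compounds shown alone.

Measured compounds, in a functional assay on PC-12 cells (Rattus norvegicus) for cytotoxicity, read by MTT assay, with stated times of 3 h and 2 h, tested at 20 uM; a lower number here means a weaker effect, a higher number a stronger effect of the compound at the concentration tested:
Compound 1 `CC(=O)c1cc2ccc(OCCCn3cc(CNC(=O)CCCCC4CCSS4)nn3)cc2oc1=O` gives 39.8%.
Compound 2 `CCOC(=O)c1cc2ccc(OCCCn3cc(CNC(=O)CCCCC4CCSS4)nn3)cc2oc1=O` gives 42.1%.
Compound 3 `CC(=O)c1cc2ccc(OCCCCCn3cc(CNC(=O)CCCCC4CCSS4)nn3)cc2oc1=O` gives 20.7%.

Compound 1 and compound 2 share a core and differ by ethoxy in place of methyl on a carbonyl carbon; that change gave a step of a number 2.3 percentage points higher from compound 1 to compound 2 (within the scatter), within the scatter. The difference between the core of compound 1 and the core of compound 3 is not broken down here. In this assay compound 3 stands lowest of the three, with compound 1 nearest and compound 2 furthest, both beyond the scatter.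

Compound 4 `CCOC(=O)c1cc2ccc(OCCCCCn3cc(CNC(=O)CCCCC4CCSS4)nn3)cc2oc1=O` differs from compound 3 by ethoxy in place of methyl on a carbonyl carbon, the same kind of change as from compound 1 to compound 2, at a place described in the same words. Because the earlier step of a number 2.3 percentage points higher from compound 1 to compound 2 (within the scatter) lay within the scatter, the step from compound 3 to compound 4 is expected to be small as well, estimated at a number 2.3 percentage points higher from compound 3 to compound 4 (within the scatter). On that basis compound 4 is expected to give about 23% in this assay, estimated between 12% and 34%.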

Compound 4, a percentage reported as activity, at one concentration (the size of the read-out at that concentration, not a potency): 39.5%
Compound 4: middle estimate off by 16.5 percentage points, on the low side; the whole stated range lies below it.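

In this assay, the change from acetyl to ethoxycarbonyl gave a number 18.8 percentage points higher from compound 3 to compound 4 (beyond the scatter). The same change did not carry over with the same size from one core to the other: the same change on two cores in this assay, a number 2.3 percentage points higher (within the scatter) from compound 1 to compound 2 and a number 18.8 percentage points higher (beyond the scatter) from compound 3 to compound 4, 16.5 percentage points apart, beyond the scatter of two such steps

This shows that, in these two pairs, the size of the step varies with the core, but it does not show which feature of the cores is responsible, and two pairs give no rule for any further core. The compounds shown leave open how the step would run on a core with a longer chain than that of compound 3. They also leave open whether a carboxylic acid or a primary amide on the carbonyl carbon would follow the ethoxy compounds.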